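The compounds below may be only part of what the source reports. "The series", "measured", "known", "first", "only" and "open" are said of these compounds alone.

Measured so far:
- compound 1 `CCC(=O)Oc1c(C(C)C)cc2c3c1OC(=O)[C@@]31CCCC(C)(C)[C@@H]1CC2`: 113000 nM
- compound 2 `CCCCC/C=C/C/C=C/CCCCCCCC(=O)Oc1c(C(C)C)cc2c3c1OC(=O)[C@@]31CCCC(C)(C)[C@@H]1CC2`: 253000 nM

In an ADME assay on AGS cells (Homo sapiens) for cytotoxicity, read by neutral red uptake, with a stated time of 24 h (a higher number here means a weaker inhibitor, a lower number a stronger inhibitor), compound 1 gives 113000 nM, the lower of the two numbers, and the gap to compound 2 lies beyond the usual scatter. Compound 3 `CC(C)c1cc2c3c(c1OC(=O)Cc1c[nH]c4ccccc14)OC(=O)[C@@]31CCCC(C)(C)[C@@H]1CC2` changes compound 1 in one place: 1H-indol-3-yl in place of methyl on a saturated chain carbon bound to a carbonyl carbon. Compound 2, with its far longer chain, still reads 253000 nM, so a large swing seems unlikely. No change beyond the scatter is expected, and the estimated move is a 1.1-fold lower number from compound 1 to compound 3 (0.05 log units; within the scatter). For compound 3 the expected value is 100000 nM, with an estimated range from 40000 nM to 250000 nM.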

Compound 3, half-maximal inhibitory concentration: 85600 nM
The estimate for compound 3 lay 1.2-fold (0.07 log units) above the measured number; the range from low to high includes it.
By their numbers in this assay, from the lowest: compounds 3 and 1 (each within the scatter of the next); then compound 2.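

In this assay, placing 1H-indol-3-yl in place of methyl on a saturated chain carbon bound to a carbonyl carbon gives a 1.3-fold lower number from compound 1 to compound 3 (0.12 log units; within the scatter), so this large addition of two aromatic rings and a hydrogen-bond donor leaves the reading within the scatter. At this position, then, the size of the change does not by itself bring a clear shift in the number. No available measurement explains this result. Still open, on these data alone, is whether an amine or a carboxylic acid at this place would shift the number, and whether a phenyl would read like 1H-indol-3-yl.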